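A Second Methoxy Group on a Sulfonamide Scaffold

This account rests on a few compounds, and the source may have more. Where it says the series, first, only, none or still open, it means among the compounds named here.

Compound 1, `COc1ccc(CN(c2cc(OC)c(OC)c(OC)c2)S(=O)(=O)c2ccc(C)cc2)cc1`: in a functional assay on MCF7 cells (Homo sapiens) for inhibition, read by MTT assay, with a stated time of 48 h (a lower number here means a stronger inhibitor, a higher number a weaker inhibitor), compound 1 gives 10100 nM.
Compound 2, `COc1cc(N(Cc2ccccc2)S(=O)(=O)c2ccc(C)cc2)cc(OC)c1OC`: compound 2 gives 10200 nM.
Compound 3, `COc1ccc(N(Cc2nc3ccccc3[nH]2)S(=O)(=O)c2ccc(C)cc2)cc1`: compound 3 reaches only a limit of the assay, > 50000 nM.

Compounds 1 and 2 share a core and differ by a single change, (methoxy in place of hydrogen on an aromatic carbon). The step is a 1.0-fold lower number from compound 2 to compound 1 (0.00 log units; within the scatter), so the two numbers read as one and the same. The difference between the core of compound 2 and that of compound 3 is not broken down here. For compound 3 the value is a limit and not a number; the point the limit of > 50000 nM in this assay, at which 1 of the 3 values shown sits, is where one of the three results sits.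

The unmeasured compound 4, `COc1ccc(N(Cc2nc3ccccc3[nH]2)S(=O)(=O)c2ccc(C)cc2)cc1OC`, is related to compound 3 by methoxy in place of hydrogen on an aromatic carbon. This is the same kind of change as from compound 2 to compound 1, but the surroundings differ: in compound 1 the new group stands para to a large group, whereas in compound 4 it stands ortho to a methoxy group and meta to a large group.

For compound 4 the expected step in this assay is an at least 1.1-fold lower number from compound 3 to compound 4 (0.04 log units; that floor lies within the scatter), resting on the earlier step of a 1.0-fold lower number from compound 2 to compound 1 (0.00 log units; within the scatter), which shows no movement, and on compound 3 sitting at > 50000 nM. Compound 4 is therefore estimated at 45000 nM, between 15000 nM and 150000 nM, with a fair chance that the assay again reports only a limit.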

Compound 4, half-maximal inhibitory concentration: > 50000 nM
Compound 4: only a limit was reported; the forecaster's own chance of this, stated with the estimate: 65%; middle value at least 1.1-fold (0.04 log units) away from the limit.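

Compound 4, like compound 3, reaches only a limit in this assay, so no step can be read between compound 3 and compound 4, and both stand at the same point: the limit of > 50000 nM in this assay, at which 2 of the 4 values shown sit.

The compounds shown leave open whether methoxy in place of hydrogen on an aromatic carbon changes the number at all on the core of compound 3, and how far beyond that limit either compound lies.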